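A few compounds are considered here, and "the series" means these few. Any claim that something is new, unique, unknown or untested is made for them only; others in the source may bear on it.

Values in a functional assay on A549 cells (Homo sapiens) for inhibition, read by sulforhodamine B assay, with a stated time of 72 h; a lower number here means a stronger inhibitor, a higher number a weaker inhibitor:
compound 1 `Nc1sc(-c2ccc(Cl)cc2)c(-c2ccc(Cl)cc2)c1C(=O)N1CCCCC1=O` gives 1820 nM
compound 2 `CCCCNC(=O)c1c(N)sc(-c2ccc(Cl)cc2)c1-c1ccc(Cl)cc1` gives 8170 nM
compound 3 `CC(C)(C)NC(=O)c1c(N)sc(-c2ccc(Cl)cc2)c1-c1ccc(Cl)cc1` gives 8850 nM

Compound 3 stands together with compound 2 on the weaker side of compound 1, with no separation between the two. Compound 4 `COc1ccc(CNC(=O)c2c(N)sc(-c3ccc(Cl)cc3)c2-c2ccc(Cl)cc2)cc1` carries 4-methoxybenzyl in place of tert-butyl on an amide-type nitrogen. The closest evidence is a swap on that same nitrogen (a 1.1-fold higher number from compound 2 to compound 3 (0.03 log units; within the scatter)). Larger are a 4.5-fold higher number from compound 1 to compound 2 (0.65 log units; beyond the scatter) and a 4.9-fold higher number from compound 1 to compound 3 (0.69 log units; beyond the scatter) but both replace 2-oxopiperidin-1-yl, and no measured compound carries 4-methoxybenzyl. In this assay the expected step is a 1.3-fold lower number from compound 3 to compound 4 (0.10 log units; within the scatter) so no shift beyond the scatter is expected. Compound 4 is estimated at 7000 nM (expected range 2500 nM to 18000 nM).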

Compound 4, half-maximal inhibitory concentration: 18200 nM
Compound 4: middle estimate off by 2.6-fold (0.41 log units), on the low side; measured number above the stated range.
By their numbers in this assay, from the lowest: compound 1; then compounds 2 and 3 (each within the scatter of the next); then compound 4.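

In this assay the amide-type nitrogen now separates its substituents: 4-methoxybenzyl in place of tert-butyl gives a weaker result (a 2.1-fold higher number from compound 3 to compound 4 (0.31 log units; beyond the scatter)), whereas butyl and tert-butyl did not separate. Against butyl the direction is the same (a 2.2-fold higher number from compound 2 to compound 4 (0.35 log units; beyond the scatter)), and the gap to the 2-oxopiperidin-1-yl amide of compound 1 widens (a 10-fold higher number from compound 1 to compound 4 (1.00 log units; beyond the scatter)). No measured evidence accounts for these steps. Still open, going by these compounds, is whether the added ring or the methoxy group carries the shift; an unsubstituted benzyl on that nitrogen would separate the two.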